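The compounds below may be only part of what the source reports. "The series", "measured", "known", "first", "only" and "open" are said of these compounds alone.

Two compounds share one core and differ in a single group. Compound 1 `CC1=C(C(=O)Nc2ccc([N+](=O)[O-])cc2)C(c2cccc([N+](=O)[O-])c2)N=C(SCc2ccccc2Cl)N1` carries a 2-chlorophenyl on a saturated chain carbon bound to a sulfur, and in a functional assay on the whole organism (artery, strain albino) with Rattus norvegicus as the target, with a stated time of 30 min, at a dose of 10 mg/kg by the oral route (a higher number here means more inhibition at the dose given (going by the name of the read-out), a lower number less inhibition), compound 1 gives 3.6%. Compound 2 `CC1=C(C(=O)Nc2ccc([N+](=O)[O-])cc2)C(c2cccc([N+](=O)[O-])c2)N=C(SCc2ccc(Cl)cc2)N1` carries a 4-chlorophenyl at that place, and in this assay compound 2 gives 3.1%. Among the measured compounds shown here, the one measured step is a number 0.5 percentage points lower from compound 1 to compound 2 (within the scatter), so the two numbers lie within the usual scatter of each other and neither compound can be called the weaker or the stronger. Compound 3 `CC1=C(C(=O)Nc2ccc([N+](=O)[O-])cc2)C(c2cccc([N+](=O)[O-])c2)N=C(SCc2ccc(F)cc2)N1` is not yet measured; it differs from compound 2 by fluoro in place of chloro on an aromatic carbon. For the measured compounds named here, no measured step concerns a fluoro for chloro exchange; the only step measured is the one just named, and it stayed within the scatter. The step for compound 3 is therefore expected to be a number 0.4 percentage points higher from compound 2 to compound 3 (within the scatter), nothing beyond the scatter. Compound 3 is estimated at 3.5%, between -6% and 13%.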

Compound 3, a percentage reported as inhibition, in the whole organism at one dose (the size of the read-out at that dose, not a potency): 4.1%
The estimate for compound 3 lay 0.6 percentage points below the measured number; the measured number falls inside the stated range.
By their numbers in this assay, from the lowest: compounds 2, 1 and 3 (each within the scatter of the next).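

Compounds 1 and 2 differ only in where the chlorine sits, whereas this pair exchanges the halogen itself, on an aromatic carbon para to a large group. In this assay the exchange of chloro for fluoro gives a number 1 percentage points higher from compound 2 to compound 3 (within the scatter) and so the two compounds cannot be told apart. Exchanging the halogen and its place on the ring together gives a number 0.5 percentage points higher from compound 1 to compound 3 (within the scatter) and this pair also cannot be told apart, while no measurement at hand offers an explanation for these results.

The compounds shown leave open whether any group of a different kind on this ring, such as a methoxy group, an amine or a carboxylic acid, would give a number beyond the scatter. They also leave open what a longer chain between the sulfur and the ring would give.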